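The compounds below may be only part of what the source reports. "The series", "measured", "known", "first", "only" and "open" are said of these compounds alone.

In a functional assay on HeLa cells (Homo sapiens) for inhibition, read by CCK-8 assay, with a stated time of 72 h, tested at 2 uM (a higher number here means more inhibition of growth at the concentration tested, a lower number less inhibition of growth), the measured compounds read as follows:

- compound 1 `COc1ccc(SCc2ccc(C(=O)Nc3ccccc3N)cc2)cc1` gives 35%
- compound 2 `Nc1ccccc1NC(=O)/C=C/c1ccc(CSc2ccc(C(F)(F)F)cn2)cc1` gives 6.07%
- compound 3 `COc1ccc(SCc2ccc(C(=O)Nc3ccccc3N)cc2)cc1OC` gives 15.2%

Compound 1 stands highest of the three numbers, with compound 3 nearest and compound 2 furthest. The next compound, compound 4 `Nc1ccccc1NC(=O)c1ccc(CSc2ccc(F)cc2)cc1`, is not yet measured in this assay. It departs from compound 1 by a single exchange fluoro in place of methoxy on an aromatic carbon that puts fluoro in place of methoxy on an aromatic carbon, para to a large group.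

For the measured compounds named here, only one measured step bears on this exchange. Compound 3 shows a number 19.8 percentage points lower from compound 1 to compound 3 (beyond the scatter) with methoxy in place of hydrogen on an aromatic carbon. That step is modest but beyond the scatter, and it shows that a change on this ring can move the number. Going by the values given here, it does not tell what fluoro does, since no measured compound carries that group. Compound 2 differs from compound 1 in more than one place and offers no clean comparison.

A small downward move is therefore expected, with a real chance of no change beyond the scatter. The estimated step is a number 9 percentage points lower from compound 1 to compound 4 (within the scatter). This expected size stays below that of the step from compound 1 to compound 3. Compound 4 is estimated at 26% (expected range 10% to 42%).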

Compound 4, percent growth inhibition at one concentration: 27.9%
The estimate for compound 4 lay 1.9 percentage points below the measured number; low and high end bracket the measured number.
By their numbers in this assay, from the lowest: compounds 2 and 3 (each within the scatter of the next); then compounds 4 and 1 (each within the scatter of the next).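

In this assay, the exchange of 4-methoxyphenyl for 4-fluorophenyl gives a number 7.1 percentage points lower from compound 1 to compound 4 (within the scatter), so this change on an aromatic carbon, para to a large group, cannot be told from the usual variation between repeated measurements. For the compounds shown here, the only earlier step on this ring, a number 19.8 percentage points lower from compound 1 to compound 3 (beyond the scatter), added a second methoxy and showed that the number can respond to a change there; the new step shows that the methoxy of compound 1 can give way to fluoro, which has fewer heavy atoms and no hydrogen-bond acceptor, with no change beyond the scatter. No measurement shown offers an explanation for this result.

Going by these compounds, whether chloro, an amine or a carboxylic acid at this place would also stay within the scatter of compound 1 remains open. On these data alone, it is also open whether a longer chain on the oxygen of the methoxy would leave this assay as little moved as fluoro does.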